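The source may hold more compounds than are shown below. What is called first, only, known or untested is meant among the compounds shown, and "the series" means these compounds.

Series values in a functional assay on DU-145 cells (Homo sapiens) for inhibition, read by trypan blue exclusion, with a stated time of 96 h; on this read-out higher numbers stand for weaker inhibition of growth and lower numbers for stronger inhibition of growth:
- compound 1 `O=C(O)c1ccc(C(=O)/C(=C\c2ccc(F)c([N+](=O)[O-])c2)SCc2ccc(C(F)(F)F)cc2)cc1`: 1000 nM
- compound 2 `O=C(O)c1ccc(C(=O)/C(=C\c2ccc(Cl)c([N+](=O)[O-])c2)SCc2ccc(C(F)(F)F)cc2)cc1`: 1000 nM
- compound 3 `O=C(/C(=C\c1ccc(Cl)cc1Cl)Sc1ccc(Br)cc1)c1ccc(Br)cc1`: 1000 nM

Compound 1 and compound 3 stand level with compound 2 at 1000 nM, so none of the three separates from the others on these numbers. The next compound to consider is compound 4 `O=C(O)c1ccc(C(=O)/C(=C\c2ccc(Cl)c([N+](=O)[O-])c2)SCc2ccc(Cl)cc2Cl)cc1`, which keeps the core of compound 2 and changes one group: 2,4-dichlorophenyl in place of 4-(trifluoromethyl)phenyl on a saturated chain carbon bound to a sulfur. In words, this is 2,4-dichlorophenyl in place of 4-(trifluoromethyl)phenyl on a saturated chain carbon bound to a sulfur.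

Within the data shown here, only one measured step is available, no change at the digits printed from compound 1 to compound 2 (within the scatter). It is a chloro in place of fluoro on an aromatic carbon, so it does not touch the place that changes here. Among the measured compounds shown here, no measured step tests this exchange directly, and the evidence is thin. With nothing in the series moving beyond the scatter, no step beyond the scatter is expected in this assay. The expected step is no change at the digits printed from compound 2 to compound 4 (within the scatter). For compound 4 the estimate is 1000 nM, with an expected range from 400 nM to 2500 nM.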

Compound 4, concentration for 50% growth inhibition: 1000 nM
For compound 4 middle estimate and measured number coincide at the digits printed; the measured number falls inside the stated range.
By their numbers in this assay, from the lowest: compounds 1, 2, 3 and 4 (each within the scatter of the next).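

In this assay the place on a saturated chain carbon bound to a sulfur now has a measured exchange: 2,4-dichlorophenyl in place of 4-(trifluoromethyl)phenyl gives no change at the digits printed from compound 2 to compound 4 (within the scatter) on the core of compound 2. Among these compounds, the earlier step, a chloro in place of fluoro on an aromatic carbon, did not touch this place, so this is the first reading here, and it shows that these two substituted phenyl groups do not separate at the digits printed. No measurement bears on why the value stays level.

Still open, going by these compounds, is whether a group of another kind at this place, such as an aminoalkyl chain or an unsubstituted hexyl chain, would give a step beyond the scatter. A single exchange also leaves open whether this result holds on a core other than that of compound 2.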